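Methyl to bromomethyl on the core of compound 1

The compounds below may be only part of what the source reports. "The series", "measured", "known", "first", "only" and "open" are said of these compounds alone.

Measured in a functional assay (microsomes, liver) with Rattus norvegicus as the target; on this read-out higher numbers stand for weaker inhibition and lower numbers for stronger inhibition:
compound 1 `Cc1c(C)c2c(c(C)c1N)CC(C)(C)O2`: 760 nM
compound 2 `Cc1c(C)c2c(c(N)c1N)CC(C)(C)O2`: 300 nM
compound 3 `Cc1c(N)c(C)c2c(c1CC(C)C)OC(C)(C)C2`: 140 nM

Compound 1 carries the highest number of the three in this assay. The two measured steps from it are a 2.5-fold lower number from compound 1 to compound 2 (0.40 log units; beyond the scatter) and a 5.4-fold lower number from compound 1 to compound 3 (0.73 log units; beyond the scatter), both modest and both beyond the scatter.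

Compound 4 `Cc1c(C)c2c(c(C)c1N)CC(C)(CBr)O2` is not yet measured. It differs from compound 1 as follows: bromo in place of hydrogen on a saturated chain carbon bound to a saturated ring carbon. This is bromo in place of hydrogen on a saturated chain carbon bound to a saturated ring carbon, or methyl to bromomethyl.

Within the data shown here, no measured step falls at this place. The nearest guide is the isopropyl change, which also replaces hydrogen on a saturated chain carbon, though one bound to an aromatic carbon, and gave a 5.4-fold lower number from compound 1 to compound 3 (0.73 log units; beyond the scatter). The amino change, a 2.5-fold lower number from compound 1 to compound 2 (0.40 log units; beyond the scatter), bears on it less. A small shift toward a lower number is therefore expected, possibly not beyond the scatter.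

The expected step is a 1.7-fold lower number from compound 1 to compound 4 (0.23 log units; within the scatter).

For compound 4 the estimated value is 450 nM, with an expected range of 150 nM to 1200 nM.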

Compound 4, half-maximal inhibitory concentration: 300 nM
Beside the measured number, compound 4's estimate is 1.5-fold (0.18 log units) above it, and the stated range covers the measured number.
By their numbers in this assay, from the lowest: compound 3; then compounds 2 and 4 (each within the scatter of the next); then compound 1.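

In this assay, the step of a 2.5-fold lower number from compound 1 to compound 4 (0.40 log units; beyond the scatter) shows that a saturated chain carbon bound to a saturated ring carbon is a place on the shared core where a change moves the number beyond the scatter. Among these compounds, the earlier steps covered only an aromatic carbon and a saturated chain carbon bound to an aromatic carbon, so this is the only reading at this position, and here the entering group is a single bromine atom. Nothing available bears on why the number moves at this position.

Bromo is the only group shown on this carbon, so it remains open whether the step is specific to bromo. Chloro, hydroxy, an amine or a longer chain at the same place would test this.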